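The source may report more compounds than this note shows. Statements on the series, on what has been measured and on what is new or still open speak of the compounds shown alone.

Working notes on the series, read in a functional assay on MOLT-4 cells (Homo sapiens) for antiproliferative activity; on this read-out higher numbers stand for weaker inhibition and lower numbers for stronger inhibition. Of the compounds shown here, two sharing one core have been measured so far. Compound 1 (`COc1cc(C(=O)c2sc(-c3ccc(I)cc3)cc2N)cc(OC)c1OC`) gives 190 nM and compound 2 (`COc1cc(C(=O)c2sc(-c3ccc(Cl)c(Cl)c3)cc2N)cc(OC)c1OC`) gives 270 nM. Among the compounds with values here, the one measured step, a 1.4-fold higher number from compound 1 to compound 2 (0.15 log units; within the scatter), leaves compound 2 level with compound 1 within the scatter, and it is the nearest reference point.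

Compound 3 (`COc1cccc(-c2cc(N)c(C(=O)c3cc(OC)c(OC)c(OC)c3)s2)c1`) is still to be measured in this assay. Its change from compound 2 falls at the same place on the core: 3-methoxyphenyl in place of 3,4-dichlorophenyl on an aromatic carbon. This puts 3-methoxyphenyl in place of 3,4-dichlorophenyl on an aromatic carbon next to the ring sulfur.

Within the data shown here, only the step of a 1.4-fold higher number from compound 1 to compound 2 (0.15 log units; within the scatter) bears on this place, and it is small. Among the measured compounds shown here, no measured compound carries 3-methoxyphenyl, so the data give no firm direction, and one step is thin evidence. A step within the scatter is therefore expected, with a wide range around it. The estimated step is a 1.3-fold higher number from compound 2 to compound 3 (0.11 log units; within the scatter). For compound 3 the expected value is 350 nM, with an estimated range of 100 nM to 1300 nM.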

Compound 3, half-maximal inhibitory concentration: 17 nM
Compound 3: middle estimate off by 21-fold (1.31 log units), on the high side; measured number outside the range, below it.
By their numbers in this assay, from the lowest: compound 3; then compounds 1 and 2 (each within the scatter of the next).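

In this assay, the position on the aromatic carbon next to the ring sulfur proves far more responsive than the near-level pair of compound 1 and compound 2 could show, with a 16-fold lower number from compound 2 to compound 3 (1.20 log units; beyond the scatter) and an 11-fold lower number from compound 1 to compound 3 (1.05 log units; beyond the scatter). Two different halogen-bearing phenyl groups therefore sit within the scatter of each other, while 3-methoxyphenyl stands clearly apart from both, so the outcome at this position is not set by the presence of a phenyl ring alone. The swap from 3,4-dichlorophenyl keeps the heavy-atom count and the six-membered aromatic ring, and changes the atoms on that ring from chlorine to oxygen and the hydrogen-bond acceptor count from none to one, but no measurement here gives a reason for the large step.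

The compounds shown leave open whether the step follows from the methoxy group itself or from the loss of the halogens, a question that unsubstituted phenyl would help to separate. On these data alone, whether a larger ether such as ethoxy or a hydroxy group on the same ring would hold the low number also stays open.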